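The source may report more compounds than this note shows. Statements on the series, on what has been measured and on what is new or still open speak of the compounds shown alone.

In a toxicity assay on HUVEC cells (Homo sapiens) for inhibition (a higher number here means a weaker inhibitor of growth, a lower number a stronger inhibitor of growth), the measured compounds are:
compound 1 `Cc1nc(-c2ccccc2)c(C(=O)N2CCN(c3cccc(C#N)c3)CC2)o1` gives 2.52 ug/mL;
compound 2 `Cc1nc(-c2ccccc2)c(C(=O)N2CCN(c3ccccc3)CC2)o1` gives 9.63 ug/mL;
compound 3 `Cc1nc(-c2ccccc2)c(C(=O)N2CCN(c3ccc(C)c(C)c3)CC2)o1` gives 3.52 ug/mL.

Compound 3 stands second highest of these three numbers. Its nearest neighbour is compound 1, as shown by a 1.4-fold higher number from compound 1 to compound 3 (0.15 log units; within the scatter); its furthest is compound 2, as shown by a 2.7-fold lower number from compound 2 to compound 3 (0.44 log units; beyond the scatter).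

Compound 4 `Cc1nc(-c2ccccc2)c(C(=O)N2CCN(c3cc(Cl)cc(Cl)c3)CC2)o1` differs from compound 3 in one place: 3,5-dichlorophenyl in place of 3,4-dimethylphenyl on an amine nitrogen in a ring. For the measured compounds named here, no measured step swaps one substituted phenyl for another of this kind. Going by the values given here, the steps that bear on it are a 3.8-fold higher number from compound 1 to compound 2 (0.58 log units; beyond the scatter) and a 2.7-fold lower number from compound 2 to compound 3 (0.44 log units; beyond the scatter): both show the bare phenyl giving a higher number than a substituted phenyl, while a 1.4-fold higher number from compound 1 to compound 3 (0.15 log units; within the scatter) shows two different substituted phenyls giving numbers close to each other. A 3,5-dichlorophenyl is a third substituted phenyl, so the expected step from compound 3 is small, within the scatter or at most modestly downward: a 1.4-fold lower number from compound 3 to compound 4 (0.13 log units; within the scatter). Compound 4 is therefore expected to give 2.6 ug/mL, with a range from 1 ug/mL to 6.5 ug/mL.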

Compound 4, concentration for 50% growth inhibition: 0.191 ug/mL
The estimate for compound 4 lay 14-fold (1.13 log units) above the measured number, outside the stated range (below it).
By their numbers in this assay, from the lowest: compound 4; then compounds 1 and 3 (each within the scatter of the next); then compound 2.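

On the amine nitrogen in the ring, the kind of substituted phenyl matters a great deal in this assay: 3,5-dichlorophenyl gives an 18-fold lower number from compound 3 to compound 4 (1.27 log units; beyond the scatter), a 13-fold lower number from compound 1 to compound 4 (1.12 log units; beyond the scatter) and a 50-fold lower number from compound 2 to compound 4 (1.70 log units; beyond the scatter), making compound 4 the strongest inhibitor of growth of the four. The earlier substituted phenyls, 3-cyanophenyl and 3,4-dimethylphenyl, lay within the scatter of each other, whereas this change keeps the same count of heavy atoms and still moves the number strongly, so substitution here is more than a matter of whether a group is present. Nothing available explains this large step.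

The change from compound 3 to compound 4 alters both the atoms on the phenyl and where they sit, so the compounds shown cannot separate the two. On these data alone, how a phenyl carrying one chlorine, a bromine or a methoxy group would compare also remains open.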